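The source may report more compounds than this note shows. Statements on the series, on what has been measured and on what is new or still open speak of the compounds shown alone.

The study compares two pairs of compounds in an ADME assay on RAW264.7 cells (Mus musculus) for cytotoxicity, read by MTT assay, with a stated time of 24 h; on this read-out lower numbers stand for higher toxicity in this test and higher numbers for lower toxicity in this test. Compound 1 `O=c1oc2ccc(F)cc2c(=O)n1-c1ccc(F)cc1F` and compound 2 `O=c1oc2ccc(Br)cc2c(=O)n1-c1ccc(F)cc1F` share a core in which the halogen sits on an aromatic carbon of a six-membered aromatic ring of carbon only, part of a fused or bridged system of two rings, meta to a fused ring and para to a fused ring. In this assay compound 1 gives 19900 nM, and compound 2 gives 16000 nM. The change between them is bromo in place of fluoro on an aromatic carbon and it made a 1.2-fold lower number from compound 1 to compound 2 (0.09 log units; within the scatter).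

Compound 3 `O=C(Nc1ccc(Br)cc1F)c1cc(F)ccc1O` rests on a different core; the difference between the cores of compound 1 and compound 3 is not broken down here. In this assay compound 3 gives 7900 nM, the lowest of the three numbers, beyond the scatter from compound 1 and from compound 2. Compound 4 `O=C(Nc1ccc(Br)cc1F)c1cc(Br)ccc1O` has not yet been measured. It differs from compound 3 by bromo in place of fluoro on an aromatic carbon. Among the compounds with values here, this is the same kind of change as the one from compound 1 to compound 2, but its surroundings differ: here the aromatic carbon is meta to a large group and para to a hydroxy group rather than part of a fused or bridged system. Since the earlier step of a 1.2-fold lower number from compound 1 to compound 2 (0.09 log units; within the scatter) stayed within the scatter, the expectation for compound 4 is a step of similar size, a 1.1-fold lower number from compound 3 to compound 4 (0.05 log units; within the scatter), resting on that single earlier step alone. Compound 4 is therefore estimated at 7000 nM, with a likely range from 3500 nM to 14000 nM.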

Compound 4, half-maximal cytotoxic concentration: 7800 nM
For compound 4 the middle estimate is 1.1-fold (0.05 log units) below the measured one, and the stated range covers the measured number.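

In this assay, bromo in place of fluoro on an aromatic carbon gives a 1.0-fold lower number from compound 3 to compound 4 (0.01 log units; within the scatter), so on this second core the swap again leaves the number within the scatter, even though the carbon now sits meta to a large group and para to a hydroxy group rather than in a fused system. Set side by side, the two steps agree, and in this small series the change carries from one core to the other without a step that stands out from repeated measurement: the same change on two cores in this assay, a 1.2-fold lower number (0.09 log units; within the scatter) from compound 1 to compound 2 and a 1.0-fold lower number (0.01 log units; within the scatter) from compound 3 to compound 4, 1.2-fold (0.09 log units) apart, within the scatter of two such steps This does not show that the swap would be equally quiet on any further core or in any other test, since it rests on one pair on each of two cores and on a single read-out, and two steps within the scatter say nothing of why the number holds.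

The compounds shown carry only fluoro or bromo at this place, so it remains open how the read-out would respond to an amine, a carboxylic acid or a longer chain there. Going by these compounds, it is also open whether the swap would stay as quiet on the second core with a methoxy group in place of the hydroxy group.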